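The compounds below may be only part of what the source reports. "The series", "measured", "known", "first", "only" and "open" are said of these compounds alone.

Compound 1, `COc1cc2ccc(=O)oc2cc1OCCOc1no[n+]([O-])c1S(=O)(=O)c1ccccc1`, gives 3610 nM in a functional assay on HepG2 cells (Homo sapiens) for inhibition, read by MTT assay, with a stated time of 48 h; a higher number here means a weaker inhibitor, a lower number a stronger inhibitor.
Compound 2, `COc1cc2ccc(=O)oc2cc1OCCCOc1no[n+]([O-])c1S(=O)(=O)c1ccccc1`, gives 2900 nM in this assay.
Compound 3, `COc1cc2ccc(=O)oc2cc1OCCCCCCOc1c[n+]([O-])on1`, gives 3790 nM in this assay.

Compound 2 stands at the low end of the three numbers, but the differences to compound 1 and to compound 3 both lie within the usual scatter of this assay, so the three compounds cannot be told apart on these data.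

Compound 4, `COc1cc2cc(N)c(=O)oc2cc1OCCCOc1no[n+]([O-])c1S(=O)(=O)c1ccccc1`, has not yet been measured. It differs from compound 2 in one place: amino in place of hydrogen on an aromatic carbon. Within the data shown here, nothing among the measured compounds shows what an amino group at this position does, since no measured pair differs there. Among the measured compounds shown here, with no step to lean on, the plain expectation is that compound 4 behaves much like compound 2, with any shift staying within the scatter of this assay in either direction.

On that basis compound 4 is expected to give about 2900 nM, with a plausible range from 1200 nM to 7000 nM, which means an estimated step of no change at the digits printed from compound 2 to compound 4 (within the scatter).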

Compound 4, half-maximal inhibitory concentration: 2810 nM
Compound 4: the middle estimate sits 1.0-fold (0.01 log units) above what was measured; measured number inside the range.
By their numbers in this assay, from the lowest: compounds 4, 2, 1 and 3 (each within the scatter of the next).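

Amino in place of hydrogen on an aromatic carbon, two atoms from the ring oxygen, gives a 1.0-fold lower number from compound 2 to compound 4 (0.01 log units; within the scatter) in this assay. This is the only single change shown at this position, and it shows that the position can carry an amino group, with its added hydrogen-bond donor, without a shift that can be told from the scatter. No supporting measurement is available to explain this result.

Going by these compounds, it remains open whether other groups at this position, such as a nitro group, an acetylamino group or a carboxylic acid, would also leave the number within the scatter. On these data alone, it is also open whether the amino group would behave the same way on compounds with the chain of compound 1 or the different chain and ring of compound 3.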